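The compounds below may be only part of what the source reports. "The series", "measured", "known", "first", "only" and "open" are said of these compounds alone.

Compound 1 `CC(C)c1onc(-c2ccccc2Cl)c1COc1ccc(COc2ccc(CC(=O)O)cc2)cc1`: 2500 nM
Compound 2 `CC(C)c1onc(-c2ccccc2Cl)c1COc1ccc(COc2ccc(OCC(=O)O)cc2)cc1`: 4700 nM
Compound 3 `CC(C)c1onc(-c2ccccc2Cl)c1COc1ccc(CCCC(=O)O)cc1`: 3800 nM

These three share one core and differ only at the carboxylic acid end. In an assay on HEK-293T cells for activation of Bile acid receptor (Homo sapiens), read by a luciferase reporter, with a stated time of 14 h (a higher number here means that more compound is needed for the effect, a lower number that less compound is needed), compound 1 gives 2500 nM, the lowest of the three numbers, yet the steps of a 1.9-fold higher number from compound 1 to compound 2 (0.27 log units; within the scatter) and a 1.5-fold higher number from compound 1 to compound 3 (0.18 log units; within the scatter) both lie within the scatter, so the three cannot be told apart. Compound 4 `CC(C)c1onc(-c2c(Cl)cccc2Cl)c1COc1ccc(COc2ccc(CC(=O)O)cc2)cc1` keeps the acid end of compound 1 and changes (chloro in place of hydrogen on an aromatic carbon), the 2-chlorophenyl becoming 2,6-dichlorophenyl. Among the measured compounds shown here, no measured step touches this part of the core; every measured step alters the acid end. There is no measured guide, and the expectation is a step of no size beyond the scatter, no change at the digits printed from compound 1 to compound 4 (within the scatter). Compound 4 is estimated at 2500 nM, ranging from 700 nM to 9000 nM.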

Compound 4, half-maximal effective concentration: 2000 nM
Compound 4: the middle estimate sits 1.3-fold (0.10 log units) above what was measured, and the stated range covers the measured number.
By their numbers in this assay, from the lowest: compounds 4, 1, 3 and 2 (each within the scatter of the next, the first and the last beyond it).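

Among the compounds shown here, the step of a 1.3-fold lower number from compound 1 to compound 4 (0.10 log units; within the scatter) is the first change outside the acid end, and in this assay it leaves the two compounds indistinguishable. A second chloro on this ring therefore makes no readable difference with the acid end of compound 1 in place. Nothing available gives a reason for this.

As far as these compounds go, whether a fluoro, a methyl or a trifluoromethyl in the same place would behave alike stays open. So does whether 2,6-dichlorophenyl would make as little difference with the acid ends of compound 2 or compound 3.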